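Epoxide-free diterpenoid acids at the cytotoxicity limit

The source may hold more compounds than are shown below. What is called first, only, known or untested is meant among the compounds shown, and "the series" means these compounds.

Compound 3 `C=CC(=C)[C@@H](O)C[C@H]1C(=C)CC[C@@H]2[C@]1(C)CCC[C@]2(C)C(=O)O` sits at the limit in a functional assay on SMMC-7721 cells (Homo sapiens) for cytotoxicity, read by MTT assay, with a stated time of 48 h (a higher number here means a weaker inhibitor, a lower number a stronger inhibitor), giving > 40000 nM, which is a limit of the assay and not a number. Compound 2 `C=C1CC[C@@H]2[C@](C)(CCC[C@]2(C)C(=O)O)[C@H]1CC/C(C)=C/CO` likewise reaches only the limit, giving > 40000 nM. Of the three values shown, only compound 1 `C=CC(=C)CC[C@@H]1[C@@]2(C)CCC[C@](C)(COC(=O)/C=C\c3ccc(O)cc3)[C@@H]2CC[C@@]1(C)O` yields a number, 16200 nM. Within the data shown here, the one step available, a step that the two limits leave unreadable from compound 2 to compound 3, cannot be read because both ends are limits; the limit of > 40000 nM in this assay, at which 2 of the 3 values shown sit, is all that is known of compounds 2 and 3.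

Compound 4 `C=C[C@@]1(C)O[C@H]1C[C@H]1C(=C)CC[C@@H]2[C@]1(C)CCC[C@]2(C)C(=O)O` differs from compound 3 in one place: a group of 6 heavy atoms (5 carbon, 1 oxygen; one three-membered non-aromatic ring with 1 hetero atom) in place of a group of 6 heavy atoms (5 carbon, 1 oxygen; no ring), on a saturated chain carbon bound to a saturated ring carbon. Among the measured compounds shown here, no measured step involves a three-membered ring with 1 hetero atom, so nothing shows whether this change moves the value beyond the scatter in either direction. The working expectation is that compound 4 stays near the limit, with an estimated step of a number no higher from compound 3 to compound 4 (the limit leaves the size open) no larger than the scatter. Compound 4 is therefore expected to give about 40000 nM, with a likely range from 15000 nM to 100000 nM, and a sizeable chance that only a limit is reported.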

Compound 4, half-maximal inhibitory concentration: > 40000 nM
Compound 4: no number, only a limit; the forecaster's own chance of this, stated with the estimate: 55%; the middle value lies on the limit itself.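

Compound 4 also returns only a limit, so the steps to it from compound 2 and compound 3 cannot be read: the limit of > 40000 nM in this assay, at which 3 of the 4 values shown sit.

Still open, as far as these compounds go, is whether the group with one three-membered non-aromatic ring with 1 hetero atom moves the cytotoxicity value in either direction.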